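A Cyano Group Added to the Anilino Ring of Compound 3

This account rests on a few compounds, and the source may have more. Where it says the series, first, only, none or still open, it means among the compounds named here.

Of the compounds shown here, three from this series have been tested for cytotoxicity so far. Compound 1 `CC(=O)C[C@H]1O[C@@H](On2cc(CN3C(=O)/C(=N\Nc4ccc(C#N)cc4)c4ccccc43)nn2)[C@H](OC(C)=O)[C@@H](OC(C)=O)[C@@H]1OC(C)=O` and compound 2 `CC(=O)C[C@H]1O[C@@H](On2cc(CN3C(=O)/C(=N\Nc4cccc(Cl)c4)c4ccccc43)nn2)[C@H](OC(C)=O)[C@@H](OC(C)=O)[C@H]1OC(C)=O` share one acetylated sugar carrier, while compound 3 `CC1(C)O[C@H]2O[C@H](Cn3cc(CN4C(=O)/C(=N\Nc5ccccc5)c5ccccc54)nn3)[C@H](O)[C@H]2O1` carries a different, acetonide-protected sugar. In an ADME assay on Vero cells (Chlorocebus sabaeus) for cytotoxicity, read by fluorescence and resazurin assay, with a stated time of 3 days (on this read-out lower numbers stand for higher toxicity in this test and higher numbers for lower toxicity in this test), compound 1 gives 75400 nM. In this assay compound 2 gives 87900 nM, and compound 3 gives 82100 nM. The three numbers lie close together: compound 3 stands second highest of the three, and its distance to both compound 1 and compound 2 falls within the scatter of the measurement, so no order among them can be read.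

Compound 4 `CC1(C)O[C@H]2O[C@H](Cn3cc(CN4C(=O)/C(=N\Nc5ccc(C#N)cc5)c5ccccc54)nn3)[C@H](O)[C@H]2O1` is not yet measured. It differs from compound 3 in one place: cyano in place of hydrogen on an aromatic carbon. In compound 1 the same cyano group is present on the anilino ring, and its value in this assay sits in the same range as compound 2 and compound 3, which lack it. The author therefore expects no step beyond the scatter from compound 3 to compound 4, a 1.1-fold lower number from compound 3 to compound 4 (0.03 log units; within the scatter). For compound 4 the estimated value in this assay is 76000 nM, with an expected range from 40000 nM to 150000 nM.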

Compound 4, half-maximal cytotoxic concentration: 105000 nM
For compound 4 the middle estimate is 1.4-fold (0.14 log units) below the measured one; low and high end bracket the measured number.
By their numbers in this assay, from the lowest: compounds 1, 3, 2 and 4 (each within the scatter of the next).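

Within the data shown here, the earlier compounds offered no pair differing in one place, so this is the first direct reading of phenyl to 4-cyanophenyl on the anilino ring, on the aromatic carbon para to a large group. With the acetonide-protected sugar the same on both sides, the change gives a 1.3-fold higher number from compound 3 to compound 4 (0.11 log units; within the scatter) in this assay and so shows no effect on cytotoxicity that can be told from the scatter at this position. Nothing available speaks to the reason for this result.

The compounds shown leave open whether an amine or a carboxylic acid at this same place would give a step beyond the scatter. They also leave open whether cyano in place of hydrogen would read alike on the acetylated sugar carrier of compound 1.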